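A few compounds are considered here, and "the series" means these few. Any claim that something is new, unique, unknown or untested is made for them only; others in the source may bear on it.

In a functional assay on PC-3 cells (Homo sapiens) for cytotoxicity, read by MTT assay, with a stated time of 72 h (a lower number here means a stronger inhibitor, a higher number a weaker inhibitor), compound 1 `O=C(/C=C/c1ccc([N+](=O)[O-])cc1)Nc1cc2c(Nc3ccc(F)c(Cl)c3)ncnc2cc1O[C@H]1CCOC1` gives 22800 nM, compound 2 `COc1ccc(/C=C/C(=O)Nc2cc3c(Nc4ccc(F)c(Cl)c4)ncnc3cc2O[C@H]2CCOC2)c(OC)c1` gives 2760 nM and compound 3 `COc1ccc(/C=C/C(=O)Nc2cc3c(Nc4ccc(F)c(Cl)c4)ncnc3cc2O[C@H]2CCOC2)c(OC)c1OC` gives 7670 nM, so compound 3 holds the middle place of the three. Compound 4 `O=C(/C=C/c1ccccc1[N+](=O)[O-])Nc1cc2c(Nc3ccc(F)c(Cl)c3)ncnc2cc1O[C@H]1CCOC1` keeps the shared core but differs from compound 3 as follows: 2-nitrophenyl in place of 2,3,4-trimethoxyphenyl on a double-bonded chain carbon bound to a double-bonded chain carbon. The nearest evidence is a modest step, a 3.0-fold lower number from compound 1 to compound 3 (0.47 log units; beyond the scatter), read in reverse, since compound 4 also carries a nitrophenyl. The steps of an 8.3-fold lower number from compound 1 to compound 2 (0.92 log units; beyond the scatter) and a 2.8-fold higher number from compound 2 to compound 3 (0.44 log units; beyond the scatter) are also modest. Among the compounds with values here, no measured step compares 2-nitrophenyl with 4-nitrophenyl, so the guide is imperfect. A modest rise in this assay is therefore expected, an estimated 2.0-fold higher number from compound 3 to compound 4 (0.29 log units; within the scatter). The estimate for compound 4 is 15000 nM, with an expected range from 6000 nM to 35000 nM.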

Compound 4, half-maximal inhibitory concentration: 7760 nM
Estimate against measurement, compound 4: 1.9-fold (0.29 log units) above; measured number inside the range.
By their numbers in this assay, from the lowest: compound 2; then compounds 3 and 4 (each within the scatter of the next); then compound 1.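

Swapping 4-nitrophenyl for 2-nitrophenyl on this chain carbon changes the number by itself (a 2.9-fold lower number from compound 1 to compound 4 (0.47 log units; beyond the scatter)), so among these two compounds, where the nitro group sits on the ring matters. 2-Nitrophenyl and 2,3,4-trimethoxyphenyl cannot be told apart (a 1.0-fold higher number from compound 3 to compound 4 (0.01 log units; within the scatter)), while 2,4-dimethoxyphenyl remains ahead of 2-nitrophenyl (a 2.8-fold higher number from compound 2 to compound 4 (0.45 log units; beyond the scatter)), so a nitro group does not by itself place a compound at the weak end. No measurement available here explains these differences. Still open, going by these compounds, is how a phenyl ring carrying an amine or a carboxylic acid would compare at this place.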